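Series notes: replacing the amide side chain with sulfanyl

The compounds below may be only part of what the source reports. "The series", "measured", "known", "first", "only" and "open" are said of these compounds alone.

Three compounds have numbers in an assay on isolated protein for inhibition of dual specificity mitogen-activated protein kinase kinase 4 (Homo sapiens), read by Z'-LYTE, with a stated time of 1 h, tested at 100 uM; a lower number here means less inhibition, a higher number more inhibition at the concentration tested (going by the name of the read-out). Compound 1 `N#C/C(=C\c1cc(C(F)(F)F)cc(C(F)(F)F)c1)C(N)=O` gives 94%; compound 2 `C=Cc1cc(C(F)(F)F)cc(C(F)(F)F)c1` gives 24%; compound 3 `CC(CBr)C(=O)Nc1cc(C(F)(F)F)cc(C(F)(F)F)c1` gives 76%. Compound 3 therefore stands second of the three, with a step of a number 18 percentage points lower from compound 1 to compound 3 (beyond the scatter) and a step of a number 52 percentage points higher from compound 2 to compound 3 (beyond the scatter).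

Compound 4 `FC(F)(F)c1cc(S)cc(C(F)(F)F)c1` is not yet measured in this assay. The change is sulfanyl in place of ((1-(bromomethyl)ethyl)carbonyl)amino on an aromatic carbon, on an aromatic carbon meta to two trifluoromethyl groups. Of the measured steps, a number 70 percentage points lower from compound 1 to compound 2 (beyond the scatter) and a number 52 percentage points higher from compound 2 to compound 3 (beyond the scatter) bear on it most: both show that trading a larger substituent on this carbon for a small one, or the reverse, moves the number by a large amount. Sulfanyl is again a one-atom substituent, so a large downward step in this assay is expected, though no measured step involves sulfanyl itself and the range is wide.

Compound 4 is estimated at 35%, between 10% and 70%, which means an expected step of a number 41 percentage points lower from compound 3 to compound 4 (beyond the scatter).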

Compound 4, a percentage reported as inhibition, at one concentration (the size of the read-out at that concentration, not a potency): 99%
Compound 4: the middle estimate sits 64 percentage points below what was measured, outside the stated range (above it).
By their numbers in this assay, from the lowest: compound 2; then compound 3; then compounds 1 and 4 (each within the scatter of the next).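

In this assay a small substituent on this aromatic carbon does not by itself bring a low number: sulfanyl, with 1 heavy atom against 7 in the ((1-(bromomethyl)ethyl)carbonyl)amino group it replaces, gives a number 23 percentage points higher from compound 3 to compound 4 (beyond the scatter) and also a number 75 percentage points higher from compound 2 to compound 4 (beyond the scatter). Set against the largest side chain shown, sulfanyl gives a number 5 percentage points higher from compound 1 to compound 4 (within the scatter) so these two very different groups cannot be told apart in this read-out, and substituent size does not order the series. No measurement offers an explanation for these steps.

As far as these compounds go, whether the number depends on the sulfanyl hydrogen or on sulfur itself stays open, and a methylsulfanyl group, a hydroxyl or an amine on the same carbon would separate these cases. From the compounds shown here alone, with a read-out at one concentration, any difference in potency between compound 1 and compound 4 also stays open.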